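Swapping the side chain on compound 2's amino acid ester

The source may hold more compounds than are shown below. What is called first, only, known or untested is meant among the compounds shown, and "the series" means these compounds.

Of the compounds shown here, two have been tested in a functional assay on the whole organism (Tail, strain ICR) with Mus musculus as the target, in the tail flick test, with a stated time of 120 min, at a dose of 25 umol/kg by the oral route; on this read-out lower numbers stand for a weaker effect and higher numbers for a stronger effect at the one dose given. Compound 1 `O=C(OCc1ccccc1)[C@@H]1CCCN1C(=O)CN(c1nc(Cl)nc2[nH]cnc12)C1CC1` gives 38.4% in this assay. Compound 2 `CC[C@H](C)[C@H](NC(=O)CN(c1ncnc2c1ncn2C1CCCCO1)C1CC1)C(=O)OCc1ccccc1` gives 20.4%, the lower of the two numbers, and the gap between compound 2 and compound 1 is wider than the usual scatter of repeated measurements. These two compounds differ in more than one place, so nothing can be said about which change accounts for that gap.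

Compound 3 `N=C(N)NCCC[C@H](NC(=O)CN(c1ncnc2c1ncn2C1CCCCO1)C1CC1)C(=O)OCc1ccccc1` has not been measured. It differs from compound 2 in a single place: a group of 7 heavy atoms (4 carbon, 3 nitrogen; no ring) in place of a group of 4 heavy atoms (4 carbon; no ring), on a saturated chain carbon bound to an amide-type nitrogen and a carbonyl carbon. Going by the values given here, only two compounds carry data, and neither of them shows what this particular exchange does in this assay, so there is no measured step to lean on.

With the value of compound 2 at 20.4% as the only anchor, compound 3 is expected to stay close to it, with a step of a number 1.6 percentage points higher from compound 2 to compound 3 (within the scatter) that should fall within the scatter. Compound 3 is therefore estimated at 22%, with a plausible range from 5% to 45%.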

Compound 3, a percentage reported as activity, at one dose (the size of the read-out at that dose, not a potency): 38.2%
Compound 3: the middle estimate sits 16.2 percentage points below what was measured, within the range that was stated.
By their numbers in this assay, from the lowest: compound 2; then compounds 3 and 1 (each within the scatter of the next).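

Going by these compounds alone, this is the first measured step at this position, the saturated chain carbon bound to an amide-type nitrogen and a carbonyl carbon. In this assay, putting a group of 7 heavy atoms (4 carbon, 3 nitrogen; no ring) in place of sec-butyl gives a number 17.8 percentage points higher from compound 2 to compound 3 (beyond the scatter), so the read-out does respond to what this carbon carries, at least for this one exchange. The entering group brings 3 hydrogen-bond donors and 1 hydrogen-bond acceptor where sec-butyl has none, but no measurement shown explains why the number rises, and this count is only a description of the two groups.

The compounds shown leave open whether the rise belongs to the nitrogen atoms at the end of the new group or to its carbon chain: a primary amine or a carboxylic acid on a similar chain, or a plain longer alkyl chain, would help to separate the two. As far as these compounds go, it also remains open whether the same exchange would give a similar step on a different amino acid ester or at another dose, since this is one pair read at one dose.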